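Glycinamide series: carbamoylethyl to isopropyl at the ester-bearing carbon

The source may report more compounds than this note shows. Statements on the series, on what has been measured and on what is new or still open speak of the compounds shown alone.

Of the compounds shown here, two have numbers so far. Compound 1 `NC(=O)CC[C@H](NC(=O)CN(c1ncnc2c1ncn2C1CCCCO1)C1CC1)C(=O)OCc1ccccc1` and compound 2 `O=C(CN(c1nc(Cl)nc2[nH]cnc12)C1CC1)N[C@@H](CC(=O)OCc1ccccc1)C(=O)OCc1ccccc1` were both run in a functional assay on the whole organism (Tail, strain ICR) with Mus musculus as the target, in the tail flick test, with a stated time of 120 min, at a dose of 25 umol/kg by the oral route; a lower number here means a weaker effect, a higher number a stronger effect of the compound at the dose given. In this assay compound 1 gives 22.3%, and compound 2 gives 12.1%. Compound 1 therefore stands highest of the two numbers, and its nearest neighbour, compound 2, lies lower by a gap beyond the usual scatter. The two compounds differ in more than one place, so nothing can be said about what any single change in the chain or the core contributes; the two values are all that is known.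

Compound 3 `CC(C)[C@H](NC(=O)CN(c1ncnc2c1ncn2C1CCCCO1)C1CC1)C(=O)OCc1ccccc1` has not yet been measured in this assay. It keeps the core and the glycinamide link of compound 1, and differs from it in one place: isopropyl in place of 2-carbamoylethyl on a saturated chain carbon bound to an amide-type nitrogen and a carbonyl carbon. Within the data shown here, no step between measured compounds covers this kind of exchange, so there is no number to lean on for its direction. The expected step is therefore small, a number 3.3 percentage points lower from compound 1 to compound 3 (within the scatter), and is not expected to reach beyond the scatter in either direction. For compound 3 in this assay the estimate is 19%, with a range from 7% to 32%.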

Compound 3, a percentage reported as activity, at one dose (the size of the read-out at that dose, not a potency): 25.8%
Compound 3: the middle estimate sits 6.8 percentage points below what was measured, within the range that was stated.
By their numbers in this assay, from the lowest: compound 2; then compounds 1 and 3 (each within the scatter of the next).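

In this assay, among these compounds, isopropyl in place of 2-carbamoylethyl on a saturated chain carbon bound to an amide-type nitrogen and a carbonyl carbon gives a number 3.5 percentage points higher from compound 1 to compound 3 (within the scatter), the first step at this position in which only one place differs. At this dose, the read-out therefore does not separate the two groups, even though 2-carbamoylethyl has 5 heavy atoms, 1 hydrogen-bond donor and 1 hydrogen-bond acceptor, whereas isopropyl has 3 heavy atoms and 0 of either, so in this pair these differences come with no change beyond the scatter. No measurement is available that bears on this result.

This single exchange does not show whether the position accepts other groups, and a carboxylic acid, an amine or a longer chain on the same carbon would test whether the read-out stays within the scatter of compound 1 or moves beyond it. With one dose and one stated time, the pair also leaves open whether the two compounds would still match at other doses or times.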